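The source may report more compounds than this note shows. Statements on the series, on what has been measured and on what is new or still open speak of the compounds shown alone.

Working notes on the series. Compound 1 `CC(=O)Nc1ccc(S(=O)(=O)Oc2ccccc2I)cc1` gives 17000 nM in a functional assay on HT-1080 cells (Homo sapiens) for antiproliferative activity, read by sulforhodamine B assay, with a stated time of 48 h; a higher number here means a weaker inhibitor, a lower number a stronger inhibitor. For the measured compounds named here, compound 2 `CCC(=O)Nc1ccc(S(=O)(=O)Oc2ccccc2I)cc1` gives 7200 nM in this assay; the only single-point step recorded between measured compounds is a 2.4-fold lower number from compound 1 to compound 2 (0.37 log units; beyond the scatter). Compound 3 `CCCCCC(=O)Nc1ccc(S(=O)(=O)Oc2ccccc2C(C)C)cc1` gives 6300 nM in this assay. This is the lowest of the three numbers, but the gap from compound 3 to compound 2 lies within the scatter, so those two cannot be ordered, while the gap from compound 3 to compound 1 lies beyond the scatter.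

Compound 4 `CCCCCC(=O)Nc1ccc(S(=O)(=O)Oc2ccccc2I)cc1` differs from compound 3 in one place: iodo in place of isopropyl on an aromatic carbon. Going by the values given here, no measured pair differs in this place alone. Among the compounds with values here, the one recorded step, a 2.4-fold lower number from compound 1 to compound 2 (0.37 log units; beyond the scatter), concerns the amide chain and does not bear on the ester ring. Compound 2, which carries the 2-iodophenyl ester, sits within the scatter of compound 3, and this gives no ground for a step beyond the scatter. The expectation for compound 4 is therefore a 1.1-fold lower number from compound 3 to compound 4 (0.02 log units; within the scatter), that is an estimated 6000 nM in this assay, within 2500 nM to 15000 nM.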

Compound 4, half-maximal inhibitory concentration: 9600 nM
For compound 4 the middle estimate is 1.6-fold (0.20 log units) below the measured one, within the range that was stated.
By their numbers in this assay, from the lowest: compounds 3, 2, 4 and 1 (each within the scatter of the next, the first and the last beyond it).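

With isopropyl and iodo now compared at this aromatic carbon in this assay, the change gives a 1.5-fold higher number from compound 3 to compound 4 (0.18 log units; within the scatter), so the 2-isopropylphenyl and 2-iodophenyl esters cannot be ordered when the amide chain of compound 3 is kept. With the 2-iodophenyl ester held, the chain steps read a 1.3-fold higher number from compound 2 to compound 4 (0.12 log units; within the scatter) and a 1.8-fold lower number from compound 1 to compound 4 (0.25 log units; within the scatter), so neither the propyl nor the butyl change confirms a chain effect, although the methyl change gave a 2.4-fold lower number from compound 1 to compound 2 (0.37 log units; beyond the scatter) as a step beyond the scatter. No measurement at hand bears on the cause of these results.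

The compounds shown leave open how an amine or a carboxylic acid would read in place of iodo on this aromatic carbon. They also leave open whether a longer chain on the amide would give a step beyond the scatter from compound 4.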